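Swapping a pyridine for a phenyl ring on the piperazine

The compounds below may be only part of what the source reports. "The series", "measured", "known", "first", "only" and "open" are said of these compounds alone.

Measured compounds:
Compound 1 `N#Cc1cccnc1N1CCN([C@@H]2CN[C@H](C(=O)N3CCSC3)C2)CC1`: 1.2 nM
Compound 3 `O=C([C@@H]1C[C@H](N2CCN(c3ccc(Cl)cn3)CC2)CN1)N1CCSC1`: 3.1 nM
Compound 2 `O=C([C@@H]1C[C@H](N2CCC(c3ccccc3)CC2)CN1)N1CCSC1`: 9.6 nM

In an assay on a cell-free system (plasma) for inhibition of Dipeptidyl peptidase 4 (Rattus norvegicus), read by fluorescence (on this read-out lower numbers stand for stronger inhibition and higher numbers for weaker inhibition), compound 3 holds the second highest of the three numbers. Its nearest neighbour is compound 1, which gives 1.2 nM, and the step of a 2.6-fold higher number from compound 1 to compound 3 (0.41 log units; beyond the scatter) separates the two. Compound 2, which carries a phenyl group on a carbon of its six-membered saturated ring rather than an aryl group on a ring nitrogen, gives 9.6 nM, a number higher than that of compound 3 and beyond the scatter.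

Compound 4 `O=C([C@@H]1C[C@H](N2CCN(c3ccc(Cl)cc3)CC2)CN1)N1CCSC1` differs from compound 3 in one place: 4-chlorophenyl in place of 5-chloropyridin-2-yl on an amine nitrogen in a ring. Among the measured compounds shown here, no measured pair mirrors this exchange. For the measured compounds named here, the only step that touches the same position, the step of a 2.6-fold higher number from compound 1 to compound 3 (0.41 log units; beyond the scatter), shows that exchanging one aryl group for another on that ring nitrogen shifts this assay by a modest amount. A shift of similar size, and in the weakening direction, is therefore expected here, with the outcome uncertain enough that no change beyond the scatter would not surprise. For compound 4 the estimate in this assay is 6 nM, between 2 nM and 20 nM, a step of a 1.9-fold higher number from compound 3 to compound 4 (0.29 log units; within the scatter).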

Compound 4, half-maximal inhibitory concentration: 10.3 nM
Estimate against measurement, compound 4: 1.7-fold (0.23 log units) below, within the range that was stated.
By their numbers in this assay, from the lowest: compound 1; then compound 3; then compounds 2 and 4 (each within the scatter of the next).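

The result isolates the hetero atom of the aromatic ring: both groups carry chlorine and have the same heavy-atom count, yet in this assay the exchange of that hetero atom and its hydrogen-bond acceptor for carbon gives a 3.3-fold higher number from compound 3 to compound 4 (0.52 log units; beyond the scatter). Among the compounds shown here, earlier, the only step at this amine nitrogen exchanged one pyridine-based group for another, a 2.6-fold higher number from compound 1 to compound 3 (0.41 log units; beyond the scatter), so it could not show whether a carbon-only aromatic ring would be tolerated as well as a ring with a hetero atom. The wider comparison, an 8.6-fold higher number from compound 1 to compound 4 (0.93 log units; beyond the scatter), changes both the aromatic ring and the group on it, so it sets the overall range at this position without separating the two changes, and nothing given here explains either shift.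

The compounds shown leave open whether a pyrimidin-2-yl group, with a second nitrogen in the aromatic ring, would extend this series in the same direction. They also leave open whether a nitrile on a phenyl ring would match the value of compound 1 or stay closer to that of compound 4, which would show how much the ring itself contributes.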